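A few compounds are considered here, and "the series" means these few. Any claim that something is new, unique, unknown or untested is made for them only; others in the source may bear on it.

Measured so far:
Compound 1, `Oc1nc2nonc2nc1Nc1ccc(OCC(F)(F)F)c(F)c1`: 10400 nM
Compound 2, `Oc1nc2nonc2nc1Nc1cccc(S(F)(F)(F)(F)F)c1`: 3700 nM

In an assay on mitochondria from L6 cells (Rattus norvegicus) for activation, with a stated time of 90 min (a lower number here means that less compound is needed, a higher number that more compound is needed for the effect), compound 2 gives the lowest of the two numbers; compound 1 stands at a higher number, and that gap lies beyond the scatter. Compound 3, `Oc1nc2nonc2nc1Nc1cccc(F)c1`, is not yet measured. It differs from compound 2 by one fluorine atom in place of a group of 6 heavy atoms (5 fluorine, 1 sulfur; no ring), on an aromatic carbon. Going by the values given here, no step between measured compounds of this kind is available, so the size can only be guessed; a rise of moderate size in this assay is expected. For compound 3 the estimate is 12000 nM, range 4000 nM to 40000 nM, a step of a 3.2-fold higher number from compound 2 to compound 3 (0.51 log units; beyond the scatter) expected.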

Compound 3, half-maximal effective concentration: 31200 nM
Beside the measured number, compound 3's estimate is 2.6-fold (0.41 log units) below it; low and high end bracket the measured number.
By their numbers in this assay, from the lowest: compound 2; then compound 1; then compound 3.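

In this assay, one fluorine atom in place of the group of 6 heavy atoms (5 fluorine, 1 sulfur) on the aromatic carbon gives an 8.4-fold higher number from compound 2 to compound 3 (0.93 log units; beyond the scatter). Hydrogen in place of 2,2,2-trifluoroethoxy on an aromatic carbon gives a 3.0-fold higher number from compound 1 to compound 3 (0.48 log units; beyond the scatter). Compound 3, with the smallest substituents of the three, therefore has the highest number, and both steps show that the larger groups on this ring go with less compound being needed.

Nothing at hand bears on why the number moves. As far as these compounds go, whether an amine or a methoxy group at this place would give a lower number remains open.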